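This account rests on a few compounds, and the source may have more. Where it says the series, first, only, none or still open, it means among the compounds named here.

Measured in an ADME assay on GES1 cells (Homo sapiens) for inhibition, read by MTT assay, with a stated time of 72 h; a higher number here means a weaker inhibitor, a lower number a stronger inhibitor:
compound 1 `Cc1cc(Nc2cc(-c3ccccc3)[nH]n2)n2nc(SCc3cccc4ccccc34)nc2n1` — 36300 nM
compound 2 `Cc1ccc(Cn2ccc(Nc3cc(C)nc4nc(SCc5ccc(Br)cc5)nn34)n2)cc1` — > 50000 nM, a limit, not a number
compound 3 `C#CCSc1nc2nc(C)cc(Nc3cc(-c4ccccc4)[nH]n3)n2n1` — 45700 nM

Compound 2 stands at the limit of > 50000 nM in this assay, at which 1 of the 3 values shown sits; no number is available for it, only the limit, so its place relative to compound 1 and compound 3 cannot be fixed beyond that.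

The step under consideration leads to compound 4 `Cc1cc(Nc2ccn(Cc3csc4ccc(Cl)cc34)n2)n2nc(SCc3ccc(Br)cc3)nc2n1`, which differs from compound 2 by 5-chloro-1-benzothiophen-3-yl in place of 4-methylphenyl on a saturated chain carbon bound to an aromatic nitrogen. Among the compounds with values here, the only measured step in the set, a 1.3-fold higher number from compound 1 to compound 3 (0.10 log units; within the scatter), sits on a saturated chain carbon bound to a sulfur, a different place from the carbon bound to an aromatic nitrogen that is changed here, so it does not bear directly on this change. What it does show is that a swap of the aryl group on that chain moved this assay by no more than the scatter. Within the data shown here, no measured step speaks to the place changed in compound 4, and no direction can be argued from the set.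

On that basis compound 4 is expected to land near the limit at which compound 2 sits, and the step is estimated as an at least 1.1-fold lower number from compound 2 to compound 4 (0.04 log units; that floor lies within the scatter). Compound 4 is estimated at 45000 nM, with a range from 15000 nM to 150000 nM, and a good chance that only a limit is again reported.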

Compound 4, half-maximal inhibitory concentration: 31400 nM
Compound 4: the middle estimate sits 1.4-fold (0.16 log units) above what was measured; low and high end bracket the measured number.
By their numbers in this assay, from the lowest: compounds 4, 1 and 3 (each within the scatter of the next). At a limit, above all of these: compound 2.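

In this assay, the saturated chain carbon bound to an aromatic nitrogen now has its first reading: 5-chloro-1-benzothiophen-3-yl in place of 4-methylphenyl gives an at least 1.5-fold lower number from compound 2 to compound 4 (0.20 log units; that floor lies within the scatter). Compound 2 stands at > 50000 nM, which is a limit and not a number. Compound 4 gives a number at this place, 31400 nM. The step to it has only a floor, so its true size stays open and no direction beyond the scatter can be claimed: the limit of > 50000 nM in this assay, at which 1 of the 4 values shown sits.

Within the data shown here, open is which part of the entering group matters, the chlorine, the sulfur-containing five-membered ring or the larger ring system as a whole, and whether the same change would give a similar reading with the sulfur-bound chain of compound 1 or compound 3 in place of the one shared by compound 2 and compound 4. Also open is how this assay would read with an amine, a carboxylic acid or a longer chain at the saturated carbon bound to the aromatic nitrogen, where only two aryl groups are shown so far.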